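The compounds below may be only part of what the source reports. "The series", "measured", "known", "first", "only" and "open" are said of these compounds alone.

Measured compounds:
- compound 1, `CN(C(=N)Nc1cccc2ccccc12)c1cccc2ccccc12`: 4800 nM
- compound 2, `CN(C(=N)N(C)c1cccc2ccccc12)c1cccc2ccccc12`: 10700 nM
- compound 3, `CCc1cccc(NC(=N)N(C)c2cccc3ccccc23)c1`: 1000 nM

All three numbers come from an assay on membranes from brain (Cavia porcellus) for binding affinity to Sigma non-opioid intracellular receptor 1 (Homo sapiens), read by radioligand binding; a higher number here means a weaker inhibitor, a lower number a stronger inhibitor. Compound 3 gives the lowest number of the three; compound 1 gives a higher number and compound 2 a higher number still, and both gaps to compound 3 lie beyond the usual scatter. How the core of compound 3 differs from the core of compound 1 is not broken down here.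

One change appears twice in the set. From compound 1 to compound 2 it is methyl in place of hydrogen on a nitrogen on an aromatic ring and in this assay it made a 2.2-fold higher number from compound 1 to compound 2 (0.35 log units; beyond the scatter). The same change leads from compound 3 to the unmeasured compound 4, `CCc1cccc(N(C)C(=N)N(C)c2cccc3ccccc23)c1`: methyl in place of hydrogen on a nitrogen on an aromatic ring. The two descriptions of the place agree word for word, so it is taken as the same change on a different core.

Among the compounds with values here, with only one earlier example, the expectation for compound 4 rests on that single step. The step from compound 3 to compound 4 in this assay is expected to be a 2.2-fold higher number from compound 3 to compound 4 (0.34 log units; beyond the scatter), a modest rise of the number, because the same change gave a 2.2-fold higher number from compound 1 to compound 2 (0.35 log units; beyond the scatter). Whether the second core answers in the same way is not shown by any other pair here, so the range is kept wide. Compound 4 is therefore estimated at 2200 nM, within about 1000 nM to 5000 nM.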

Compound 4, half-maximal inhibitory concentration: 1210 nM
Compound 4: the middle estimate sits 1.8-fold (0.26 log units) above what was measured; the range from low to high includes it.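

In this assay the second reading of methyl in place of hydrogen on a nitrogen on an aromatic ring is a 1.2-fold higher number from compound 3 to compound 4 (0.08 log units; within the scatter) and so, on the core of compound 3, the step stays inside the usual scatter. Set beside the first reading, the two steps do not differ by more than two such steps would scatter, so a single shared size for the change on both cores remains compatible with the data, even though only the first step lies beyond the scatter: the same change on two cores in this assay, a 2.2-fold higher number (0.35 log units; beyond the scatter) from compound 1 to compound 2 and a 1.2-fold higher number (0.08 log units; within the scatter) from compound 3 to compound 4, 1.8-fold (0.27 log units) apart, within the scatter of two such steps. This does not show that the change carries over unaltered to other cores, nor does it fix the size of the step, since two cores with one pair each support no general rule.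

The compounds shown leave open how this nitrogen responds to anything larger than methyl, such as an ethyl group or a longer chain, or to an acetyl group. They also leave open whether the step stays this size on a core bearing a methoxy group or a carboxylic acid in place of the ethyl group of compound 3.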